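Moving a Fluorine Around a Ring: Clearance in Rat Hepatocytes

The compounds below may be only part of what the source reports. "The series", "measured", "known", "first", "only" and "open" are said of these compounds alone.

Measured compounds:
Compound 1 `O=C(O)COC(=O)N(C1CC1)[C@H]1c2ccccc2N(C(=O)c2cccc(F)c2)[C@H]2CC[C@H]21`: 20 uL/min
Compound 2 `O=C(O)CCC(=O)N(C1CC1)[C@H]1c2ccccc2N(C(=O)c2ccc(F)cc2)[C@H]2CC[C@H]21`: 14 uL/min

In an ADME assay on cells (Hepatocyte, Rattus norvegicus) for metabolic stability (on this read-out higher numbers stand for fast clearance and lower numbers for slow clearance), compound 2 gives 14 uL/min, the lower of the two numbers shown, yet its nearest neighbour, compound 1, sits within the usual scatter of it, so no order can be claimed. Compound 3 `O=C(O)CCC(=O)N(C1CC1)[C@H]1c2ccccc2N(C(=O)c2cccc(F)c2)[C@H]2CC[C@H]21` differs from compound 2 in a single place: 3-fluorophenyl in place of 4-fluorophenyl on a carbonyl carbon. Going by the values given here, no measured pair mirrors this change, so no step of known size can guide it. In this assay the step from compound 2 to compound 3 is expected to be small, a 1.2-fold higher number from compound 2 to compound 3 (0.08 log units; within the scatter), likely within the scatter. Compound 3 is therefore estimated at 17 uL/min, between 9 uL/min and 34 uL/min.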

Compound 3, intrinsic clearance in a liver preparation (reported as CLH), per the amount of preparation that the assay uses: 16 uL/min
Compound 3: middle estimate off by 1.1-fold (0.03 log units), on the high side; the range from low to high includes it.
By their numbers in this assay, from the lowest: compounds 2, 3 and 1 (each within the scatter of the next).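

Placing 3-fluorophenyl in place of 4-fluorophenyl on a carbonyl carbon gives a 1.1-fold higher number from compound 2 to compound 3 (0.06 log units; within the scatter) in this assay, so this move of the fluorine leaves no readable difference. Going by these compounds alone, the first measured pair for the acid-bearing side chain, 2-carboxyethyl in place of carboxymethoxy on a carbonyl carbon, gives a 1.3-fold lower number from compound 1 to compound 3 (0.10 log units; within the scatter), which also cannot be told apart from repeat-to-repeat noise. Nothing available explains either result. Going by these compounds, whether plain phenyl or 3-chlorophenyl on that carbonyl carbon, or a longer chain ending in a carboxylic acid, would produce a step beyond the scatter remains open.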